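Aryl substituent changes across compounds 1 to 4

This account rests on a few compounds, and the source may have more. Where it says the series, first, only, none or still open, it means among the compounds named here.

Measured so far in a functional assay on OVCAR-3 cells (Homo sapiens) for inhibition, read by MTT assay, with a stated time of 24 h; a higher number here means a weaker inhibitor, a lower number a stronger inhibitor:
compound 1 `COc1ccccc1-n1cc(CN2C(=O)C[C@@H]3CC[C@@]2(C)C3(C)C)nn1` gives 140 nM
compound 2 `COc1ccc(-n2cc(CN3C(=O)C[C@@H]4CC[C@@]3(C)C4(C)C)nn2)cc1` gives 250 nM
compound 3 `CC1(C)[C@H]2CC[C@]1(C)N(Cc1cn(-c3cccc(Br)c3)nn1)C(=O)C2` gives 30 nM

Compound 1 stands second highest of the three numbers. Its nearest neighbour is compound 2, with a 1.8-fold higher number from compound 1 to compound 2 (0.25 log units; within the scatter); its furthest is compound 3, with a 4.7-fold lower number from compound 1 to compound 3 (0.67 log units; beyond the scatter). Between the other two the spread is an 8.3-fold lower number from compound 2 to compound 3 (0.92 log units; beyond the scatter).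

Compound 4 `CC1(C)[C@H]2CC[C@]1(C)N(Cc1cn(-c3ccccc3F)nn1)C(=O)C2` is not yet measured in this assay . It differs from compound 1 by fluoro in place of methoxy on an aromatic carbon.

Going by the values given here, two measured steps bear on it, both loosely. The step from compound 1 to compound 2 keeps the methoxy and only shifts it, and stays within the scatter. The step from compound 1 to compound 3 exchanges the methoxy for a halogen at another position and lowers the number modestly. Among the compounds with values here, no measured compound carries a fluoro, and none changes the group while keeping it at the place it occupies in compound 1, so the direct evidence is thin. Within the data shown here, a small step, if any, is expected, leaning toward a lower number because a 4.7-fold lower number from compound 1 to compound 3 (0.67 log units; beyond the scatter) is the only halogen-for-methoxy exchange seen.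

Compound 4 is therefore expected near 100 nM, within 35 nM to 300 nM, which amounts to an expected 1.4-fold lower number from compound 1 to compound 4 (0.15 log units; within the scatter).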

Compound 4, half-maximal inhibitory concentration: 300 nM
Compound 4: middle estimate off by 3.0-fold (0.48 log units), on the low side; measured number inside the range.
By their numbers in this assay, from the lowest: compound 3; then compounds 1, 2 and 4 (each within the scatter of the next, the first and the last beyond it).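

In this assay, fluoro in place of methoxy on an aromatic carbon, ortho to a large group, gives a 2.1-fold higher number from compound 1 to compound 4 (0.33 log units; beyond the scatter), so a halogen on this ring does not by itself bring the low number of compound 3, and at this place the exchange moves the number the other way. The aryl group now carries a wider spread than the methoxy shift suggested: 2-fluorophenyl and 3-bromophenyl are separated by a 10-fold higher number from compound 3 to compound 4 (1.00 log units; beyond the scatter), whereas a 1.2-fold higher number from compound 2 to compound 4 (0.08 log units; within the scatter) leaves 2-fluorophenyl within the scatter of 4-methoxyphenyl, and of the four compounds only compound 3 lies beyond the scatter of all the others. No available evidence accounts for these differences.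

Compound 3 and compound 4 differ in both the halogen and its place on the ring, so the compounds shown do not settle which of the two follows the gap. Also open, from the compounds shown here alone, is how the number responds when this ring carries an amine or a carboxylic acid rather than a halogen or methoxy.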